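This account rests on a few compounds, and the source may have more. Where it says the series, first, only, none or still open, it means among the compounds named here.

Among the compounds with values here, in an assay on cells for displacement of a labelled ligand from Glucagon receptor (Homo sapiens), in the presence of a further agent that is not named here (a higher number here means a weaker inhibitor, a lower number a stronger inhibitor), compound 1 `CCCC(Oc1ccc(-n2cc(Cl)cn2)cc1)c1ccc(C(=O)NCCC(=O)O)cc1` gives 1100 nM, the highest number among the three compounds measured so far. Compound 3 `CCCC(Oc1ccc(-n2cc(C(F)(F)F)cn2)nc1)c1ccc(C(=O)NCCC(=O)O)cc1` gives 230 nM and compound 2 `CCCC(Nc1cc(C)c(-n2cc(C(F)(F)F)cn2)c(C)c1)c1ccc(C(=O)NCCC(=O)O)cc1` gives 12 nM; both lie beyond the scatter below compound 1, with compound 2 the furthest away. Compound 4 `CCCC(Oc1ccc(-n2cc3c(n2)CCCC3)cc1)c1ccc(C(=O)NCCC(=O)O)cc1` has not been measured. It differs from compound 1 in one place: a group of 9 heavy atoms (7 carbon, 2 nitrogen; one five-membered aromatic ring with 2 hetero atoms, one six-membered non-aromatic ring of carbon only) in place of a group of 6 heavy atoms (3 carbon, 2 nitrogen, 1 chlorine; one five-membered aromatic ring with 2 hetero atoms), on an aromatic carbon. Within the data shown here, no measured pair here shows this same change, so the size of the step is open, and the lower numbers of compound 2 and compound 3 point, if anything, downward. The step expected is a 2.0-fold lower number from compound 1 to compound 4 (0.30 log units; within the scatter), small enough that it may still sit within the scatter. Compound 4 is estimated at 550 nM, within a range from 150 nM to 2000 nM.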

Compound 4, inhibition constant: 690 nM
Estimate against measurement, compound 4: 1.3-fold (0.10 log units) below; the measured number falls inside the stated range.
By their numbers in this assay, from the lowest: compound 2; then compound 3; then compounds 4 and 1 (each within the scatter of the next).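

On an aromatic carbon para to a large group, the 4-chloro-1H-pyrazol-1-yl group gives way to a larger group with a second, six-membered non-aromatic ring, and this yields a 1.6-fold lower number from compound 1 to compound 4 (0.20 log units; within the scatter) in this assay. Within the data shown here, at this position, then, going from 6 to 9 heavy atoms produces no step that can be told from scatter. Nothing available here bears on the reason for this result. Still open, from the compounds shown here alone, is what an amine or a hydroxyl group on that non-aromatic ring would do, and how a morpholine ring would compare in this place.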